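Thiophene for Furan on a Fused Nucleoside Core

The compounds below may be only part of what the source reports. "The series", "measured", "known", "first", "only" and "open" are said of these compounds alone.

Measured compounds:
compound 1, `O=c1[nH]cnc2c1c(-c1ccoc1)cn2[C@@H]1O[C@H](CO)[C@@H](O)[C@H]1O`, 12100 nM
compound 2, `COc1ncnc2c1c(-c1ccoc1)cn2[C@@H]1O[C@H](CO)[C@@H](O)[C@H]1O`, 290 nM

In a functional assay on HepG2 cells (Homo sapiens) for antiproliferative activity, read by XTT assay, with a stated time of 72 h (on this read-out higher numbers stand for weaker inhibition and lower numbers for stronger inhibition), compound 1 stands at the highest of the two numbers, while compound 2 shows a markedly lower number, a gap that lies beyond the scatter. Compound 3, `O=c1[nH]cnc2c1c(-c1ccsc1)cn2[C@@H]1O[C@H](CO)[C@@H](O)[C@H]1O`, is not yet measured in this assay. It differs from compound 1 in one place: thiophen-3-yl in place of furan-3-yl on an aromatic carbon. Among the compounds with values here, no step between measured compounds covers this kind of exchange, so its size is uncertain. The step of a 1.3-fold lower number from compound 1 to compound 3 (0.13 log units; within the scatter) is expected to stay within the scatter or move only slightly lower. Compound 3 is therefore estimated at 9000 nM, within 3000 nM to 27000 nM.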

Compound 3, half-maximal inhibitory concentration: > 15000 nM
Compound 3 was reported as a limit (the forecaster's own chance of this, stated with the estimate: 10%); middle value at least 1.6-fold (0.22 log units) away from the limit.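

Compound 3 is reported only as a limit in this assay, > 15000 nM. Thiophen-3-yl in place of furan-3-yl on this aromatic carbon gives an at least 1.2-fold higher number from compound 1 to compound 3 (0.09 log units; that floor lies within the scatter), so sulfur for oxygen in the five-membered ring brings no stronger inhibition here, while the true size of the step stays unknown. Only a floor can be read from this result: the limit of > 15000 nM in this assay, at which 1 of the 3 values shown sits.

Open, on these data alone, is whether thiophen-3-yl would act the same way on the methoxy core of compound 2, which gives 290 nM. Also open, as far as these compounds go, is how an amine or a phenyl group would read on this aromatic carbon.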